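Working notes: chain extension from compound 2 to compound 3

The source may report more compounds than this note shows. Statements on the series, on what has been measured and on what is new or still open speak of the compounds shown alone.

Measured compounds:
compound 1, `O=c1ccn([C@@H]2O[C@H](COP(=O)(O)OP(=O)(O)OP(=O)(O)O)[C@@H](O)[C@@H]2O)c(=S)[nH]1`: in an in vitro functional assay on 1321-N1 cells for agonist activity at P2Y purinoceptor 4 (Homo sapiens), read by scintillation proximity assay and inositol phosphate accumulation (a higher number here means that more compound is needed for the effect, a lower number that less compound is needed), compound 1 gives 7930 nM
compound 2, `O=c1ccn([C@@H]2O[C@H](COP(=O)(O)OP(=O)(O)OP(=O)(O)OP(=O)(O)O)[C@@H](O)[C@H]2O)c(=S)[nH]1`: in this assay compound 2 gives 5520 nM

Among the measured compounds shown here, compound 2 stands at the lower of the two numbers so far, but compound 1 sits within the usual scatter of it, so no order between the two is claimed. For the measured compounds named here, compounds 1 and 2 also differ from each other in more than one place, so their pair gives no single isolated step; all that can be said is what the two values show, namely two numbers close together.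

Compound 3, `O=c1ccn([C@@H]2O[C@H](COP(=O)(O)OP(=O)(O)OP(=O)(O)OP(=O)(O)OP(=O)(O)O)[C@@H](O)[C@H]2O)c(=S)[nH]1`, is the next compound to be measured. It differs from compound 2 by a group of 4 heavy atoms (3 oxygen, 1 phosphorus; no ring) in place of a hydrogen atom, on an oxygen, the new group sitting on an oxygen whose other neighbour is phosphorus.

Going by the values given here, no pair of measured compounds isolates a change of this kind, so there is nothing in the set that points to a direction. Among the compounds with values here, the two measured values lying within scatter of each other is the only guide, and it suggests a step in this assay of no more than the scatter, with no preferred sign. Compound 3 is therefore estimated at 6000 nM, with a range of 2000 nM to 18000 nM, meaning an expected step of a 1.1-fold higher number from compound 2 to compound 3 (0.04 log units; within the scatter).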

Compound 3, half-maximal effective concentration: 5270 nM
Compound 3: middle estimate off by 1.1-fold (0.06 log units), on the high side; low and high end bracket the measured number.
By their numbers in this assay, from the lowest: compounds 3, 2 and 1 (each within the scatter of the next).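

Working notes after compound 3: in this assay, replacing a hydrogen atom with the new group, on an oxygen whose other neighbour is phosphorus, gives the first single-place step in the series, a 1.0-fold lower number from compound 2 to compound 3 (0.02 log units; within the scatter). Compounds 1 and 2 differ in more than one place and could not isolate any change, whereas this pair shows that, at this oxygen, this group leaves the number within the scatter, so the position accepts the added group with no readable effect in this pair. No measured data bear on why the step is this small, and no explanation for it is offered here.

Going by these compounds, it remains open whether a different group on the same oxygen, such as a methyl group, an amine or a longer chain, would move the number beyond the scatter. Among the compounds shown here, also open is whether this step would read the same on the core of compound 1, since only the pair of compound 2 and compound 3 isolates it.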